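The compounds below may be only part of what the source reports. "The series", "measured", "known", "first", "only" and "open" are said of these compounds alone.

Measured so far in this series:
- compound 1 `CCCCC1([C@H](O)/C=C/[C@H]2COC(=O)N2CCSc2nc(C(=O)O)cs2)CCC1`: in an assay on isolated protein for agonist activity at prostaglandin E2 receptor EP4 subtype (Homo sapiens) (on this read-out lower numbers stand for an effect already at smaller amounts and higher numbers for an effect only at larger amounts of compound), compound 1 gives 73 nM
- compound 2 `CC(C)(C)CCC1([C@H](O)/C=C/[C@H]2COC(=O)N2CCSc2nc(C(=O)O)cs2)CCC1`: in this assay compound 2 gives 4710 nM
- compound 3 `CC(C)(CCCCF)[C@H](O)/C=C/[C@H]1COC(=O)N1CCSc1nc(C(=O)O)cs1`: in this assay compound 3 gives 1220 nM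

Compound 2 carries the highest number of the three in this assay. Compound 3 stands nearest to it, a 3.9-fold lower number from compound 2 to compound 3 (0.59 log units; beyond the scatter), and compound 1 furthest, a 65-fold higher number from compound 1 to compound 2 (1.81 log units; beyond the scatter).

The next compound, compound 4 `CC#CCC1([C@H](O)/C=C/[C@H]2COC(=O)N2CCSc2nc(C(=O)O)cs2)CCC1`, differs from compound 2 in one place: prop-1-yn-1-yl in place of neopentyl on a saturated chain carbon bound to a saturated ring carbon. Seen one bond further out, the 3,3-dimethylbutyl chain on the cyclobutyl carbon becomes a but-2-yn-1-yl chain.

The step that bears on this is a 65-fold higher number from compound 1 to compound 2 (1.81 log units; beyond the scatter), where the same chain was grown from butyl to 3,3-dimethylbutyl and the number rose strongly. Among the measured compounds shown here, compound 4 returns that chain to the length of the butyl chain in compound 1, but with a triple bond that no measured compound carries. The steps involving compound 3 concern the other side of the ring and speak only to where compound 2 stands. A large drop in this assay is therefore expected, reversing much but perhaps not all of a 65-fold higher number from compound 1 to compound 2 (1.81 log units; beyond the scatter). Compound 4 is estimated at 150 nM, range 40 nM to 600 nM, meaning an expected 31-fold lower number from compound 2 to compound 4 (1.50 log units; beyond the scatter).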

Compound 4, half-maximal effective concentration: 240 nM
Estimate against measurement, compound 4: 1.6-fold (0.20 log units) below; the range from low to high includes it.
By their numbers in this assay, from the lowest: compound 1; then compound 4; then compound 3; then compound 2.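

In this assay, the loss seen in a 65-fold higher number from compound 1 to compound 2 (1.81 log units; beyond the scatter) proves largely reversible at this position: replacing neopentyl with prop-1-yn-1-yl gives a 20-fold lower number from compound 2 to compound 4 (1.29 log units; beyond the scatter) and brings back most of the lost ground. Among the compounds shown here, the triple bond is the first unsaturation read on this chain, and prop-1-yn-1-yl in place of propyl gives a 3.3-fold higher number from compound 1 to compound 4 (0.52 log units; beyond the scatter), so the but-2-yn-1-yl chain is tolerated but does not fully match the butyl chain. The 1-(but-2-yn-1-yl)cyclobutyl group also compares favourably with 5-fluoro-1,1-dimethylpentyl, with a 5.1-fold lower number from compound 3 to compound 4 (0.71 log units; beyond the scatter) on that change, and nothing at hand accounts for any of these shifts.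

The compounds shown leave open how much of the recovery belongs to the triple bond and how much to the loss of the terminal branching in the 3,3-dimethylbutyl chain; a but-2-en-1-yl or 3-methylbutyl chain on the same cyclobutyl carbon would help separate the two. Also open, on these data alone, is how far the chain can grow once it carries a triple bond, which a pent-2-yn-1-yl chain would test.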